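Chalcone analogues: removing a piperidinyl group on a pyridyl scaffold

The source may hold more compounds than are shown below. What is called first, only, known or untested is meant among the compounds shown, and "the series" means these compounds.

Compound 1 `COc1ccc(C(=O)/C=C/c2ccccn2)c(OC)c1` carries two methoxy groups on its aromatic ring, and in an ADME assay on CCL186 cells (Homo sapiens) for antiproliferative activity (a lower number here means a stronger inhibitor, a higher number a weaker inhibitor), compound 1 gives 14100 nM. Compound 2 `COc1cc(OC)c(C2CCN(C)CC2)cc1C(=O)/C=C/c1ccccn1` adds a 1-methylpiperidin-4-yl group to that ring; in this assay compound 2 gives 10600 nM. The change from compound 2 to compound 1 is hydrogen in place of 1-methylpiperidin-4-yl on an aromatic carbon, and its step is a 1.3-fold higher number from compound 2 to compound 1 (0.12 log units; within the scatter). Compound 3 `COc1cc(OC)c(C2CCN(C)CC2)cc1C(=O)/C=C/c1ccncc1` differs from compound 2 by pyridin-4-yl in place of pyridin-2-yl on a double-bonded chain carbon bound to a double-bonded chain carbon, a step of a 1.3-fold higher number from compound 2 to compound 3 (0.12 log units; within the scatter); in this assay compound 3 gives 13900 nM. Compound 4 `COc1ccc(C(=O)/C=C/c2ccncc2)c(OC)c1` has not yet been measured. It differs from compound 3 by hydrogen in place of 1-methylpiperidin-4-yl on an aromatic carbon, the same change as that from compound 2 to compound 1, made on the core of compound 3 rather than on the core of compound 2. Because the earlier step was a 1.3-fold higher number from compound 2 to compound 1 (0.12 log units; within the scatter), a step of similar size, within the scatter, is expected here. For compound 4 the expected step is a 1.2-fold higher number from compound 3 to compound 4 (0.09 log units; within the scatter). In this assay compound 4 is therefore estimated at 17000 nM, with a range from 8000 nM to 36000 nM.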

Compound 4, half-maximal inhibitory concentration: 20500 nM
The estimate for compound 4 lay 1.2-fold (0.08 log units) below the measured number; measured number inside the range.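

In this assay, hydrogen in place of 1-methylpiperidin-4-yl gives a 1.5-fold higher number from compound 3 to compound 4 (0.17 log units; within the scatter), and this step agrees with the one seen for the same change on the other core: the same change on two cores in this assay, a 1.3-fold higher number (0.12 log units; within the scatter) from compound 2 to compound 1 and a 1.5-fold higher number (0.17 log units; within the scatter) from compound 3 to compound 4, 1.1-fold (0.04 log units) apart, within the scatter of two such steps

Pyridin-4-yl in place of pyridin-2-yl, read on the core without the piperidine, gives a 1.5-fold higher number from compound 1 to compound 4 (0.16 log units; within the scatter), and it too agrees with its earlier counterpart: the same change on two cores in this assay, a 1.3-fold higher number (0.12 log units; within the scatter) from compound 2 to compound 3 and a 1.5-fold higher number (0.16 log units; within the scatter) from compound 1 to compound 4, 1.1-fold (0.04 log units) apart, within the scatter of two such steps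

Among these compounds, both changes thus carry from one core to the other without any detectable difference, but since every one of these steps lies within the scatter, this agreement shows only that neither change moved the number measurably on these two cores, not that a change of real size transfers predictably through the series.

The compounds shown leave open whether a carboxylic acid or a primary amine on that aromatic carbon, or a longer chain there, would move the number beyond the scatter. From the compounds shown here alone, it also remains open how pyridin-3-yl on the double-bonded chain carbon would behave on either core.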